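The source may hold more compounds than are shown below. What is called first, only, known or untested is meant among the compounds shown, and "the series" means these compounds.

In a functional assay on the whole organism (strain NMRI) for inhibition, with Mus musculus as the target, in the formalin test, with a stated time of 30 min, at a dose of 30 umol/kg by the intraperitoneal route (on this read-out higher numbers stand for more inhibition at the one dose given (going by the name of the read-out) and lower numbers for less inhibition), two compounds have been measured so far:

- compound 1 `S=c1[nH]nc(-c2ccccc2Sc2ccccc2Cl)o1` gives 16.8%
- compound 2 `Nc1nnc(-c2ccccc2Sc2ccccc2)o1` gives 16.6%

Among the measured compounds shown here, compound 2 sits within the scatter of compound 1, so the two numbers give no step in this assay to work from; what they show is that a thione with a chloro and an amino group without one land in the same place.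

Compound 3 `Nc1nnc(-c2ccccc2Sc2ccccc2Cl)o1` has not yet been measured. It differs from compound 2 in one place: chloro in place of hydrogen on an aromatic carbon. Because compound 1, which carries the same chloro, gives 16.8% in this assay and that number lies within the scatter of compound 2, no step beyond the scatter is expected from this change. The expected step of a number 0.4 percentage points higher from compound 2 to compound 3 (within the scatter) is therefore small and in no clear direction. For compound 3 the estimate in this assay is 17%, with a range from 5% to 30%.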

Compound 3, a percentage reported as inhibition, in the whole organism at one dose (the size of the read-out at that dose, not a potency): 26.7%
Beside the measured number, compound 3's estimate is 9.7 percentage points below it; measured number inside the range.
By their numbers in this assay, from the lowest: compounds 2, 1 and 3 (each within the scatter of the next, the first and the last beyond it).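

In this assay, among the compounds shown here, chloro in place of hydrogen on an aromatic carbon, ortho to a large group, gives the first step that can be read beyond the scatter: a number 10.1 percentage points higher from compound 2 to compound 3 (beyond the scatter). With the chloro held constant, replacing the thione of compound 1 with the amino group of compound 3 gives a number 9.9 percentage points higher from compound 1 to compound 3 (within the scatter), so this exchange does not separate the two compounds. Nothing shown here speaks to the reason for the chloro step.

Only hydrogen and chloro are shown at this carbon, so it remains open whether a fluoro, a methyl or a methoxy group there would give a similar step. Also open, as far as these compounds go, is whether chloro elsewhere on the same ring would do so, and how a methylamino or an acetamido group would compare with the amino group.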